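Replacing the nitrobenzyl arm: expectation for compound 4

A few compounds are considered here, and "the series" means these few. Any claim that something is new, unique, unknown or untested is made for them only; others in the source may bear on it.

Compound 1 `CCSc1sc(-n2nc(C)c(Cc3ccccc3[N+](=O)[O-])c2C(=O)O)nc1-c1ccc(Cl)c(Cl)c1` gives 59000 nM in a functional assay on BJAB cells (Homo sapiens) for antiproliferative activity, with a stated time of 4 days; on this read-out higher numbers stand for an effect only at larger amounts of compound and lower numbers for an effect already at smaller amounts. Compound 2 `Cc1nn(-c2nc(-c3ccc(Cl)c(Cl)c3)c(SC(C)C)s2)c(C(=O)O)c1Cc1ccccc1[N+](=O)[O-]` gives 20000 nM in this assay, and compound 3 `Cc1ccccc1-c1c(C)nn(-c2nc(-c3ccc(Cl)c(Cl)c3)c(SC(C)C)s2)c1C(=O)O` gives 5500 nM. On these numbers compound 2 stands second highest of three: a 3.0-fold lower number from compound 1 to compound 2 (0.47 log units; beyond the scatter), and a 3.6-fold lower number from compound 2 to compound 3 (0.56 log units; beyond the scatter).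

Compound 4 `Cc1nn(-c2nc(-c3ccc(Cl)c(Cl)c3)c(SC(C)C)s2)c(C(=O)O)c1-c1cc(C#N)cc(C(F)(F)F)c1` is not yet measured. It differs from compound 2 in one place: 3-cyano-5-(trifluoromethyl)phenyl in place of 2-nitrobenzyl on an aromatic carbon. Going by the values given here, the one measured step that bears on this change also replaced 2-nitrobenzyl with a phenyl ring, 2-methylphenyl, on an aromatic carbon: a 3.6-fold lower number from compound 2 to compound 3 (0.56 log units; beyond the scatter). Compound 4 carries a phenyl ring with different substituents, 3-cyano-5-(trifluoromethyl)phenyl, so the size of the step is less certain than its direction, which is expected to follow that precedent. The expected step from this change is a 3.3-fold lower number from compound 2 to compound 4 (0.52 log units; beyond the scatter), modest and beyond the scatter. Compound 4 is therefore estimated at 6000 nM in this assay, within a range from 2000 nM to 20000 nM.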

Compound 4, half-maximal effective concentration: 3600 nM
The estimate for compound 4 lay 1.7-fold (0.22 log units) above the measured number; low and high end bracket the measured number.
By their numbers in this assay, from the lowest: compounds 4 and 3 (each within the scatter of the next); then compound 2; then compound 1.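

In this assay the step of a 5.6-fold lower number from compound 2 to compound 4 (0.74 log units; beyond the scatter) points the same way as the step to compound 3, so a lower number on replacing 2-nitrobenzyl at this aromatic carbon, next to the ring atom that bears a carboxy group, is not tied to 2-methylphenyl. With a 1.5-fold lower number from compound 3 to compound 4 (0.18 log units; within the scatter) and that step within the scatter, 3-cyano-5-(trifluoromethyl)phenyl and 2-methylphenyl are not separated here, although the two rings carry different substituents. Nothing available explains the lower numbers of these two compounds relative to compound 2.

As far as these compounds go, whether a phenyl ring with no substituent, or one bearing an amine or a carboxylic acid, would fall in the same range remains open. Also open, from the compounds shown here alone, is whether the same replacement carries over to the ethyl thioether of compound 1.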